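The compounds below may be only part of what the source reports. "The series", "measured", "known", "first", "only" and "open" are said of these compounds alone.

Among the compounds with values here, in a functional assay on PC-3 cells (Homo sapiens) for antiproliferative activity, read by MTT assay, with a stated time of 48 h (a higher number here means a weaker inhibitor, a lower number a stronger inhibitor), compound 2 (`COc1ccc(CN(C(=O)Cn2cc(Cn3ccc4ccccc43)nn2)c2cc(OC)c(OC)c(OC)c2)cc1`) gives 2390 nM, the higher of the two numbers so far, and compound 1 (`COc1ccc(CN(C(=O)Cn2cc(COc3ccc4ccc(=O)oc4c3)nn2)c2cc(OC)c(OC)c(OC)c2)cc1`) gives 860 nM. Next comes compound 3 (`COc1ccc(CN(C(=O)Cn2cc(CNS(=O)(=O)c3ccc(Br)cc3)nn2)c2cc(OC)c(OC)c(OC)c2)cc1`), with ((4-bromophenyl)sulfonyl)amino in place of 1H-indol-1-yl on a saturated chain carbon bound to an aromatic carbon. Within the data shown here, one measured step bears on this place, on a saturated chain carbon bound to an aromatic carbon: a 2.8-fold higher number from compound 1 to compound 2 (0.44 log units; beyond the scatter), modest but beyond the scatter. The entering group is neither of the earlier two, so that step sets no firm direction, and only a step of similar size or smaller is expected. The expected step is a 1.6-fold lower number from compound 2 to compound 3 (0.20 log units; within the scatter), a slightly lower number that stays within the scatter. Compound 3 is estimated at 1500 nM, with an expected range of 500 nM to 4500 nM.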

Compound 3, half-maximal inhibitory concentration: 12500 nM
Compound 3: middle estimate off by 8.3-fold (0.92 log units), on the low side; measured number above the stated range.
By their numbers in this assay, from the lowest: compound 1; then compound 2; then compound 3.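

In this assay, within the data shown here, the place on a saturated chain carbon bound to an aromatic carbon proves more sensitive than the first step suggested: ((4-bromophenyl)sulfonyl)amino in place of 1H-indol-1-yl gives a 5.2-fold higher number from compound 2 to compound 3 (0.72 log units; beyond the scatter), and the wider comparison gives a 15-fold higher number from compound 1 to compound 3 (1.16 log units; beyond the scatter), the only large step so far. The entering group differs from 1H-indol-1-yl in several ways at once, including its hydrogen-bond donor, its sulfonyl and its bromine, and this single step cannot separate them. No measurement at hand explains the higher number.

Still open is which of these features accounts for the step. Going by these compounds, it is also open whether a simple amine or a carboxylic acid at this place would give a lower or a higher number.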